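The source may report more compounds than this note shows. Statements on the series, on what has been measured and on what is new or still open speak of the compounds shown alone.

Measured in an ADME assay on L02 cells (Homo sapiens) for cytotoxicity, read by MTT assay, with a stated time of 72 h; on this read-out lower numbers stand for stronger inhibition and higher numbers for weaker inhibition:
- compound 1 `CC(C)/C=C/C(=O)Nc1cccc(Oc2nc(Nc3ccn(C)n3)nc3c2CSCC3)c1`: > 50000 nM
- compound 2 `C=CC(=O)Nc1cccc(Oc2nc(Nc3ccc(OC)nc3)nc3c2CSCC3)c1`: > 50000 nM
- compound 3 `C/C=C/C(=O)Nc1cccc(Oc2nc(Nc3ccc(OC)nc3)nc3c2CSCC3)c1`: > 50000 nM

All three entries are limits of this assay and not numbers, as the limit of > 50000 nM in this assay, at which 3 of the 3 values shown sit, shows. Compound 3 stands at > 50000 nM, which is a limit, so no number exists for it as a starting point.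

Compound 4 `COc1ccc(Nc2nc3c(c(Oc4cccc(NC(=O)/C=C/C(C)C)c4)n2)CSCC3)cn1` differs from it by isopropyl in place of methyl on a double-bonded chain carbon bound to a double-bonded chain carbon: prop-1-en-1-yl becomes 3-methylbut-1-en-1-yl. For the measured compounds named here, the only measured step nearby is a step that the two limits leave unreadable from compound 2 to compound 3, and it gives no size to carry over. Compound 1 already has the (3-methylbut-1-en-1-yl)carbonyl group, with a different group elsewhere on the shared core, and it gives > 50000 nM, again a limit.

With no readable step, and with all three compounds at the limit, no change beyond the scatter is expected in this assay. The expected step is a step that the limit leaves unreadable from compound 3 to compound 4. A report of only a limit is the likely outcome. For compound 4 the estimated value is 55000 nM, with an expected range of 30000 nM to 100000 nM.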

Compound 4, half-maximal inhibitory concentration: > 50000 nM
Compound 4 was reported as a limit; the forecaster's own chance of this, stated with the estimate: 85%; the middle value is on the limit's open side.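

In this assay, no new step can be read between compound 4 and compound 1, compound 2 or compound 3, because each entry is a limit: the limit of > 50000 nM in this assay, at which 4 of the 4 values shown sit.

The compounds shown leave open what half-maximal inhibitory concentration any of the four compounds has, and whether isopropyl in place of methyl shifts it at all.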